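A few compounds are considered here, and "the series" means these few. Any claim that something is new, unique, unknown or untested is made for them only; others in the source may bear on it.

Going by the values given here, compound 2 `ClCc1cccc(Cn2cnc3c(Cl)nc(Cl)nc32)c1` is the only compound with an actual number in a functional assay on SK-MEL-2 cells (Homo sapiens) for cytotoxicity, read by sulforhodamine B assay, with a stated time of 48 h (a higher number here means that more compound is tolerated, a lower number that less compound is tolerated), where compound 2 gives 10000 nM. Compound 1 `ClCc1cccc(Cn2cnc3c(Cl)ncnc32)c1` reaches only the limit > 100000 nM in this assay. Compound 3 `Nc1nc(Cl)c2ncn(Cc3cccc(CCl)c3)c2n1` differs from compound 2 in one place: amino in place of chloro on an aromatic carbon. Among the compounds with values here, the single measured step that touches this place is the one in which a chloro replaced a hydrogen there; it gave an at least 10-fold lower number from compound 1 to compound 2 (1.00 log units; beyond the scatter), though its starting point sits at the limit of > 100000 nM in this assay, at which 1 of the 2 values shown sits, so its true size remains open. Within the data shown here, compound 3 keeps a substituent at this place but exchanges the chloro for an amino, and no measured pair shows amino against chloro, so the direction is uncertain. Compound 3 is therefore expected to land somewhere between the two measured compounds, with a 3.0-fold higher number from compound 2 to compound 3 (0.48 log units; beyond the scatter) as the expected step. For compound 3 the estimate is 30000 nM, within 5000 nM to 200000 nM.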

Compound 3, concentration lethal to 50% of the cells: > 100000 nM
Compound 3: a limit, no number; the forecaster's own chance of this, stated with the estimate: 35%; at least 3.3-fold (0.52 log units) between middle value and limit.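

Amino in place of chloro on this aromatic carbon, between two ring nitrogen atoms, gives an at least 10-fold higher number from compound 2 to compound 3 (1.00 log units; beyond the scatter) in this assay. The earlier step showed only that chloro differs from hydrogen here; this one shows that a substituent at this place does not by itself bring the lower number, since among the three compounds only the chloro of compound 2 gives an actual value. The step from compound 1 to compound 3 cannot be read, because both ends are limits and not numbers: the limit of > 100000 nM in this assay, at which 2 of the 3 values shown sit.

The compounds shown leave open whether a bromo, a methoxy or a dimethylamino group at this place would give a number like that of compound 2 or a limit like those of compound 1 and compound 3. They also leave open how far compound 1 and compound 3 lie beyond their limits.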